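Chloro for Methyl on the Acid Series

The source may report more compounds than this note shows. Statements on the series, on what has been measured and on what is new or still open speak of the compounds shown alone.

Compound 1 `CS(=O)(=O)N(CCCO)c1c(Cl)c(Cl)cc2[nH]c(=O)c(=O)[nH]c12` gives 136 ng.h/mL
Compound 2 `Cc1cc2[nH]c(=O)c(=O)[nH]c2c(N(CC(=O)O)S(C)(=O)=O)c1Cl` gives 155 ng.h/mL
Compound 3 `Cc1c(Cl)cc2[nH]c(=O)c(=O)[nH]c2c1N(CC(=O)O)S(C)(=O)=O` gives 1500 ng.h/mL

In an ADME assay on the whole organism (plasma, strain Sprague-Dawley) for pharmacokinetics, with Rattus norvegicus as the target, at a dose of 5 mg/kg by the oral route (a lower number here means less compound in the circulation, a higher number more compound in the circulation at the dose given), compound 3 stands highest of the three, and the other two compounds lie lower by more than the usual scatter. Compound 4 `CS(=O)(=O)N(CC(=O)O)c1c(Cl)c(Cl)cc2[nH]c(=O)c(=O)[nH]c12` follows from compound 3 with chloro in place of methyl on an aromatic carbon and keeps the rest of the structure. Going by the values given here, no measured pair isolates this change, so any forecast is indirect. Compound 2 is an isomer of compound 3, yet compound 2 gives only 155 ng.h/mL in this read-out, which shows that a small structural difference can go with a large gap here. Compound 1 carries the same two chloro groups as compound 4 on a different chain, and compound 1 gives 136 ng.h/mL as its area under the curve. A drop of moderate size, probably beyond the scatter, is therefore expected, and the expected change is a 3.0-fold lower number from compound 3 to compound 4 (0.48 log units; beyond the scatter) in this series. The estimate for compound 4 is 500 ng.h/mL within an expected range of 130 ng.h/mL to 1600 ng.h/mL for this read-out.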

Compound 4, area under the concentration-time curve: 393 ng.h/mL
Beside the measured number, compound 4's estimate is 1.3-fold (0.10 log units) above it; measured number inside the range.
By their numbers in this assay, from the lowest: compounds 1 and 2 (each within the scatter of the next); then compound 4; then compound 3.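

In this assay, chloro in place of methyl on an aromatic carbon does not have one fixed direction. On the carbon ortho to a group of 9 heavy atoms, where compound 3 carries its methyl, the change costs exposure (a 3.8-fold lower number from compound 3 to compound 4 (0.58 log units; beyond the scatter)), whereas the same change written from compound 2 raises it (a 2.5-fold higher number from compound 2 to compound 4 (0.40 log units; beyond the scatter)). The methyl group therefore counts for more on the carbon it occupies in compound 3, and with the two chloro groups held constant, carboxy in place of 2-hydroxyethyl on the chain carbon bound to the sulfonamide nitrogen also raises the number (a 2.9-fold higher number from compound 1 to compound 4 (0.46 log units; beyond the scatter)).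

On these data alone, whether fluoro, methoxy or trifluoromethyl on that aromatic carbon would match methyl remains open, as does the effect of replacing the carboxylic acid with a primary amide. No measurement here explains why any of these steps goes the way it does.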